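Dropping the para-fluoro from a Rho kinase inhibitor

This account rests on a few compounds, and the source may have more. Where it says the series, first, only, none or still open, it means among the compounds named here.

Compound 1 `O=C(Nc1cc2cc[nH]c(=O)c2cc1Cl)C1CNCC1c1ccc(F)cc1`: 9 nM
Compound 2 `O=C(Nc1cc2cc[nH]c(=O)c2cc1Cl)C1CNCC1c1ccccn1`: 14 nM
Compound 3 `CN1CCC(C(=O)Nc2cc3cc[nH]c(=O)c3cc2Cl)CC1`: 31 nM

In an assay on isolated protein for inhibition of Rho-associated protein kinase 2 (Homo sapiens), read by a luciferase reporter (a higher number here means a weaker inhibitor, a lower number a stronger inhibitor), compound 1 gives the lowest of the three numbers; compound 2 sits within the scatter of it, while compound 3 lies beyond the scatter with a weaker number. Compound 4 `O=C(Nc1cc2cc[nH]c(=O)c2cc1Cl)C1CNCC1c1ccccc1` differs from compound 1 by hydrogen in place of fluoro on an aromatic carbon. For the measured compounds named here, the only measured step on the same aromatic ring, a 1.6-fold higher number from compound 1 to compound 2 (0.19 log units; within the scatter), swapped the whole 4-fluorophenyl for pyridin-2-yl and stayed within the scatter, so a smaller trim of one fluorine is not expected to move the number beyond the scatter either. The step of a 1.3-fold higher number from compound 1 to compound 4 (0.12 log units; within the scatter) is therefore the expected outcome. Compound 4 is estimated at 12 nM, with a range from 5 nM to 30 nM.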

Compound 4, half-maximal inhibitory concentration: 6 nM
Estimate against measurement, compound 4: 2.0-fold (0.30 log units) above; measured number inside the range.
By their numbers in this assay, from the lowest: compounds 4, 1 and 2 (each within the scatter of the next, the first and the last beyond it); then compound 3.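

Taking off the fluorine alone changes little in this assay (a 1.5-fold lower number from compound 1 to compound 4 (0.18 log units; within the scatter)), so the fluoro group is not needed for a number this low. Phenyl and pyridin-2-yl, by contrast, can be told apart (a 2.3-fold lower number from compound 2 to compound 4 (0.37 log units; beyond the scatter)), a modest step beyond the scatter that compound 1 and compound 2 alone could not show. No supporting measurement is available to explain either step. Still open, from the compounds shown here alone, is how larger groups at this place, such as methoxy or an amine, would compare with hydrogen and fluoro.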